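The source may report more compounds than this note shows. Statements on the series, on what has been measured and on what is new or still open speak of the compounds shown alone.

Four compounds built on one shared core were examined in a functional assay, tested at 200 ug/mL; a higher number here means a stronger effect of the compound at the concentration tested, a lower number a weaker effect. Compound 1, `N#CC1=C(N)OC(c2c[nH]c3ccccc23)=C(C#N)C1c1ccccc1`, gives 24.5%. Compound 2, `CN(C)c1ccc(C2C(C#N)=C(N)OC(c3c[nH]c4ccccc34)=C2C#N)cc1`, gives 20.5%; the step of a number 4 percentage points lower from compound 1 to compound 2 (within the scatter) lies within the scatter of the assay. Compound 3, `N#CC1=C(N)OC(c2c[nH]c3ccccc23)=C(C#N)C1c1ccc2ccccc2c1`, is reported as "not active" (no number reported), so compound 3 stands with no single number in this assay. The present account follows the change from compound 3 to compound 4, `Cc1ccccc1C1C(C#N)=C(N)OC(c2c[nH]c3ccccc23)=C1C#N`, which is 2-methylphenyl in place of naphthalen-2-yl on a saturated ring carbon.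

Among the measured compounds shown here, only one measured step is available, the one from compound 1 to compound 2, and it concerns a substituent on the aromatic ring rather than an exchange of the ring itself, so it does not bear directly on the change at hand; it only shows that a small decoration of that ring left the read-out within the scatter. For the measured compounds named here, no measured pair exchanges naphthalen-2-yl for a smaller aromatic group, so no step can be computed for compound 4 in this assay. Given that compound 1 with phenyl gives 24.5% and compound 3 with naphthalen-2-yl gives no number, compound 4 with 2-methylphenyl is expected to sit nearer to compound 1, with an estimated read-out of 20% and a range from 5% to 35%.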

Compound 4, a percentage reported as activity, at one concentration (the size of the read-out at that concentration, not a potency): 21.4%
For compound 4 the middle estimate is 1.4 percentage points below the measured one, within the range that was stated.
By their numbers in this assay, from the lowest: compounds 2, 4 and 1 (each within the scatter of the next).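

Among the compounds shown here, the result gives this position a number where compound 3 has none: in this assay compound 3 is reported only as "not active", so no step to it can be read, whereas the smaller 2-methylphenyl group returns a measurable read-out. The two steps that can be read are a number 3.1 percentage points lower from compound 1 to compound 4 (within the scatter) and a number 0.9 percentage points higher from compound 2 to compound 4 (within the scatter) and so phenyl, 2-methylphenyl and 4-(dimethylamino)phenyl on this saturated ring carbon cannot be told apart in this assay, whether the aromatic ring carries its added group as methyl or as dimethylamino. Nothing measured here accounts for this or ties the missing number of compound 3 to the second aromatic ring of naphthalen-2-yl.

What separates naphthalen-2-yl from the single aromatic rings therefore stays open, as the compounds shown place only one fused ring group at this carbon. Going by these compounds, it is also open whether a carboxylic acid or a hydroxyl group on the phenyl ring would move the read-out in this assay beyond the scatter, since the two added groups seen so far leave it within the scatter.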